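The compounds below may be only part of what the source reports. "The series", "measured", "known", "first", "only" and "open" are said of these compounds alone.

Compounds and values in hand: compound 1, `c1ccc2c(c1)Oc1nccnc1N1CCN=C21`, > 100000 nM; compound 2, `Clc1cccc(-c2nc(-c3cccc(C4=NCCN4)c3)no2)c1`, 30 nM; compound 3, `CC(C)c1noc(-c2ccc(C3=NCCN3)cc2)n1`, 230 nM.

In an assay for inhibition of Amine oxidase [flavin-containing] B (Homo sapiens), read by fluorescence and spectrophotometry, using microsomes, with stated times of 30 min and 20 min (a lower number here means a stronger inhibitor, a higher number a weaker inhibitor), compound 1 gives > 100000 nM, which is a limit of the assay and not a number; the note the limit of > 100000 nM in this assay, at which 1 of the 3 values shown sits, records this. Among the two numbers that remain, compound 3 sits at the higher one. Its nearest neighbour, compound 2, gives 30 nM in this assay, a lower number, and the gap between the two is beyond the scatter. Compound 2 and compound 3 differ in more than one place, so what separates them is not broken down here.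

Compound 4, `c1csc(-c2noc(-c3ccc(C4=NCCN4)cc3)n2)c1`, has not yet been measured. It departs from compound 3 by thiophen-2-yl in place of isopropyl on an aromatic carbon. Going by the values given here, no measured pair isolates this change. Taking the lower number of compound 2, whose five-membered ring carries an aromatic group, as the only guide, the step from compound 3 to compound 4 is expected to run downward, as a 2.9-fold lower number from compound 3 to compound 4 (0.46 log units; beyond the scatter), a shift beyond the scatter though modest. Compound 4 is therefore expected to give 80 nM in this assay, with a range from 25 nM to 250 nM.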

Compound 4, half-maximal inhibitory concentration: 890 nM
Estimate against measurement, compound 4: 11-fold (1.05 log units) below, and the stated range ends below it.
By their numbers in this assay, from the lowest: compound 2; then compound 3; then compound 4. At a limit, above all of these: compound 1.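

In this assay, the place on the five-membered aromatic ring with 2 nitrogen and 1 oxygen, between two ring nitrogen atoms, now has its first change that can be read on its own: thiophen-2-yl in place of isopropyl gives a 3.9-fold higher number from compound 3 to compound 4 (0.59 log units; beyond the scatter). On this pair, then, putting a five-membered aromatic ring at this place does not lower the number, and the modest size of the step shows that the larger group is accepted there at a moderate cost. Going by these compounds alone, nothing measured so far gives a reason for this step.

Left open is how a methyl group, a cyclopropyl ring or a plain phenyl ring would read at this same place, since only two groups have been compared there. As far as these compounds go, whether the same exchange would run the same way on the core of compound 2 also stays open.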